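A few compounds are considered here, and "the series" means these few. Any claim that something is new, unique, unknown or untested is made for them only; others in the source may bear on it.

Measured so far:
compound 1 `COc1cc(/C=C/C(=O)c2cccc(NC(=O)c3ccc(Cl)c(Cl)c3)c2)ccc1O` — 3.88 ug/mL
compound 2 `COc1cc(/C=C/C(=O)c2cccc(NC(=O)c3cc(Cl)cc(Cl)c3)c2)ccc1O` — 4.83 ug/mL

In a functional assay on B16 cells (Mus musculus) for inhibition (a higher number here means a weaker inhibitor, a lower number a stronger inhibitor), compound 1 gives 3.88 ug/mL and compound 2 gives 4.83 ug/mL. Compound 2 holds the higher of the two numbers, but the step of a 1.2-fold higher number from compound 1 to compound 2 (0.10 log units; within the scatter) lies within the scatter, so the two compounds are not separated by this assay. Compound 3 `CCCC(=O)Nc1cccc(C(=O)/C=C/c2ccc(O)c(OC)c2)c1` differs from compound 2 by propyl in place of 3,5-dichlorophenyl on a carbonyl carbon. Among the measured compounds shown here, the single measured step, a 1.2-fold higher number from compound 1 to compound 2 (0.10 log units; within the scatter), exchanges one dichlorophenyl for another and does not bear on replacing the aromatic group by a propyl chain; no measured pair covers such a change. The expectation for compound 3 therefore rests on compound 2 alone and carries wide bounds, set slightly toward a higher number. The expected step is a 1.2-fold higher number from compound 2 to compound 3 (0.09 log units; within the scatter). Compound 3 is estimated at 6 ug/mL, with a range from 2.5 ug/mL to 15 ug/mL.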

Compound 3, half-maximal inhibitory concentration: 1.43 ug/mL
The estimate for compound 3 lay 4.2-fold (0.62 log units) above the measured number, outside the stated range (below it).
By their numbers in this assay, from the lowest: compound 3; then compounds 1 and 2 (each within the scatter of the next).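

Propyl in place of either dichlorophenyl group on this carbonyl carbon lowers the number in this assay: (a 3.4-fold lower number from compound 2 to compound 3 (0.53 log units; beyond the scatter)) and (a 2.7-fold lower number from compound 1 to compound 3 (0.43 log units; beyond the scatter)). Among the compounds shown here, the earlier step only exchanged one dichlorophenyl for another, whereas these steps show that neither an aromatic ring nor chlorine is required here for the lowest number so far. No measurement available gives a reason for these steps.

From the compounds shown here alone, it remains open whether the lower number follows from losing the ring or the chlorines, a question that a comparison with unsubstituted phenyl or cyclohexyl on the same carbonyl carbon would address. The compounds shown also leave open how far the number depends on chain length, as with ethyl or a longer chain, or on a terminal amine or carboxylic acid.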